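Trifluoromethoxy in place of 2,2-difluoroethoxy: clearance outlook

The source may hold more compounds than are shown below. What is called first, only, known or untested is meant among the compounds shown, and "the series" means these compounds.

Compound 1, `O=C(O)Cn1nc(Cc2nc3cc(Cl)c(OCC(F)F)cc3[nH]2)c2ccccc2c1=O`: < 56.7 mL/min/kg in an ADME assay on microsomes from liver (Mus musculus) for metabolic stability (a higher number here means faster removal of the compound, a lower number slower removal), a limit of the assay.
Compound 2, `C[C@H](C(=O)O)n1nc(Cn2cc3cc(OCC4CC4)c(Cl)cc3n2)c2ccccc2c1=O`: < 66.7 mL/min/kg, a limit of the assay.
Compound 3, `O=C(O)Cn1nc(Cc2cn3cc(OCC4CC4)c(Cl)cc3n2)c2ccccc2c1=O`: < 58.4 mL/min/kg, a limit of the assay.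

Compound 1 stands at a limit of the assay rather than at a measured number. Among the measured compounds shown here, compounds 2 and 3 also sit at limits, so no step between two measured compounds can be drawn from these data.

Compound 4, `O=C(O)Cn1nc(Cc2nc3cc(Cl)c(OC(F)(F)F)cc3[nH]2)c2ccccc2c1=O`, differs from compound 1 in one place: trifluoromethyl in place of 2,2-difluoroethyl on an oxygen on an aromatic ring. For the measured compounds named here, with no measured step to lean on, the expected change in this assay is a step that the limit leaves unreadable from compound 1 to compound 4, small in either direction and within the usual scatter. Compound 4 is therefore estimated at 40 mL/min/kg, between 15 mL/min/kg and 85 mL/min/kg, most likely again reported only as a limit.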

Compound 4, clearance: < 81.7 mL/min/kg
Compound 4: no number, only a limit; the forecaster's own chance of this, stated with the estimate: 70%; the middle value lies beyond the limit too.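

Among the compounds shown here, compound 1 and compound 4 both stand only at limits in this assay, and no step between them can be read. The compounds shown leave open whether trifluoromethyl in place of 2,2-difluoroethyl changes clearance at all.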